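Permeability notes on two cores sharing one substituent swap

This account rests on a few compounds, and the source may have more. Where it says the series, first, only, none or still open, it means among the compounds named here.

Compound 1 `O=C(NCc1cc(Cl)ccc1-n1cnnn1)[C@@H]1[C@@H]2C[C@@H]2CN1C(=O)[C@H](O)Cc1ccccn1` and compound 3 `O=C(NCc1cc(Cl)ccc1-n1cnnn1)[C@@H]1C[C@@H]2C[C@@H]2N1C(=O)[C@H](O)Cc1ccccn1` are built from the same atoms joined differently; the difference between the two cores is not broken down here. In an ADME assay on Caco-2 cells (Homo sapiens) for permeability, read by LC-MS, in the apical to basolateral direction, with a stated time of 60 min, at pH 6.5 (a higher number here means that the compound crosses the layer faster, a lower number that the compound crosses the layer more slowly), compound 1 gives 0.62 10^-6 cm/s, and compound 3 gives 1.2 10^-6 cm/s; the two lie within the scatter of each other. Compound 2 `COC(C)(C)[C@@H](O)C(=O)N1C[C@H]2C[C@H]2[C@H]1C(=O)NCc1cc(Cl)ccc1-n1cnnn1` carries the change 1-methoxy-1-methylethyl in place of (pyridin-2-yl)methyl on a saturated chain carbon bound to a carbonyl carbon and an oxygen on a saturated carbon and gives 3.5 10^-6 cm/s in this assay, a step of a 5.6-fold higher number from compound 1 to compound 2 (0.75 log units; beyond the scatter). Compound 4 `COC(C)(C)[C@@H](O)C(=O)N1[C@H](C(=O)NCc2cc(Cl)ccc2-n2cnnn2)C[C@@H]2C[C@@H]21` applies the corresponding change to the core of compound 3: 1-methoxy-1-methylethyl in place of (pyridin-2-yl)methyl on a saturated chain carbon bound to a carbonyl carbon and an oxygen on a saturated carbon. The place is the same word for word, so this is the same change, occurring twice among the compounds here. Among the measured compounds shown here, the step from compound 3 to compound 4 in this assay is expected to be a 5.0-fold higher number from compound 3 to compound 4 (0.70 log units; beyond the scatter), because the single earlier instance gave a 5.6-fold higher number from compound 1 to compound 2 (0.75 log units; beyond the scatter), although one pairing is a thin basis. Compound 4 is accordingly estimated at 6 10^-6 cm/s, with a range from 2.5 10^-6 cm/s to 14 10^-6 cm/s.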

Compound 4, apparent permeability: 16 10^-6 cm/s
Beside the measured number, compound 4's estimate is 2.7-fold (0.43 log units) below it; the measured number lies above the stated range.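

In this assay the change to 1-methoxy-1-methylethyl in place of (pyridin-2-yl)methyl gives a 13-fold higher number from compound 3 to compound 4 (1.12 log units; beyond the scatter), a large step in the same direction as the one on the core of compound 1. The two instances do not differ beyond what repeated measurements allow, so the change carries from one core to the other in this series: the same change on two cores in this assay, a 5.6-fold higher number (0.75 log units; beyond the scatter) from compound 1 to compound 2 and a 13-fold higher number (1.12 log units; beyond the scatter) from compound 3 to compound 4, 2.4-fold (0.37 log units) apart, within the scatter of two such steps. This rests on one pair of groups on two cores; it says nothing about a further core, and nothing about why the number rises.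

Open, going by these compounds, is whether a tert-butyl or a benzyl group at the same place would give a step of similar size, which would show which part of the change matters.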